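Tetrahydroisoquinoline for Pyrrolidine on Two Related Cores

The compounds below may be only part of what the source reports. "The series", "measured", "known", "first", "only" and "open" are said of these compounds alone.

Compound 1 `CN(c1ccc(Oc2ncnc3ccsc23)cc1)c1nccc(N2CCCC2)n1` gives 38% in a functional assay on MDA-MB-231 cells (Homo sapiens) for inhibition, read by MTT assay, with a stated time of 72 h, tested at 20 uM; a lower number here means less inhibition, a higher number more inhibition at the concentration tested (going by the name of the read-out).
Compound 2 `CN(c1ccc(Oc2ncnc3ccsc23)cc1)c1nccc(N2CCc3ccccc3C2)n1` gives 30.2%.
Compound 3 `c1cc(N2CCCC2)nc(Nc2ccc(Oc3ncnc4sccc34)cc2)n1` gives 24.7%.

From compound 1 to compound 2 the structural change is 1,2,3,4-tetrahydroisoquinolin-2-yl in place of pyrrolidin-1-yl on an aromatic carbon, and the measured step is a number 7.8 percentage points lower from compound 1 to compound 2 (within the scatter). Compound 4 `c1ccc2c(c1)CCN(c1ccnc(Nc3ccc(Oc4ncnc5sccc45)cc3)n1)C2` has not been measured; it differs from compound 3 by 1,2,3,4-tetrahydroisoquinolin-2-yl in place of pyrrolidin-1-yl on an aromatic carbon, which is the same change at the same place. The difference between the core of compound 1 and the core of compound 3 is not broken down here. Compound 3 has the lowest of the three numbers, its gap to compound 2 lying within the scatter and its gap to compound 1 beyond it. In this assay, among the measured compounds shown here, the step to compound 4 is expected to be a number 7.7 percentage points lower from compound 3 to compound 4 (within the scatter), resting on a number 7.8 percentage points lower from compound 1 to compound 2 (within the scatter) as the only prior instance of this change. Compound 4 is therefore estimated at 17%, with an expected range from 5% to 30%.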

Compound 4, a percentage reported as inhibition, at one concentration (the size of the read-out at that concentration, not a potency): 26.8%
Compound 4: the middle estimate sits 9.8 percentage points below what was measured, and the stated range covers the measured number.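

In this assay the exchange of pyrrolidin-1-yl for 1,2,3,4-tetrahydroisoquinolin-2-yl comes out as a number 2.1 percentage points higher from compound 3 to compound 4 (within the scatter) on the core of compound 3, and the two cores do not part on this change: the same change on two cores in this assay, a number 7.8 percentage points lower (within the scatter) from compound 1 to compound 2 and a number 2.1 percentage points higher (within the scatter) from compound 3 to compound 4, 9.9 percentage points apart, within the scatter of two such steps. The change thus carries across these two cores without a discernible difference, and on neither core does its step leave the scatter. Among the compounds shown here, this rests on only two pairs at one concentration in one cell line, so it does not show that the change is neutral on other cores, nor does it say anything about potency.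

The compounds shown leave open how other amines at this position, such as morpholine or piperidine, would read. They also leave open what the difference between the two cores contributes on its own.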